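Replacing the 4-Bromophenyl Group of Compound 2

The source may hold more compounds than are shown below. What is called first, only, known or untested is meant among the compounds shown, and "the series" means these compounds.

Compound 1 `O=C(CN1CCN(c2nnc(Cc3ccccc3)c3ccccc23)CC1)Nc1c(F)cccc1F` gives 19700 nM
Compound 2 `O=C(CN1CCN(c2nnc(Cc3ccncc3)c3ccccc23)CC1)Nc1ccc(Br)cc1` gives 1990 nM

Both numbers come from a functional assay on HT-29 cells (Homo sapiens) for cytotoxicity, read by MTT assay, with a stated time of 72 h (a lower number here means a stronger inhibitor, a higher number a weaker inhibitor), and compound 2 has the lower of the two. Compound 2 at 1990 nM and compound 1 at 19700 nM are separated by a gap that lies beyond the scatter on this scale. These two compounds differ in more than one place, so the gap cannot be credited to any single group.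

Compound 3 `O=C(CN1CCN(c2nnc(Cc3ccncc3)c3ccccc23)CC1)Nc1ccc(F)c(C(F)(F)F)c1` keeps the rest of compound 2 and changes one group on the amide-type nitrogen: 4-fluoro-3-(trifluoromethyl)phenyl in place of 4-bromophenyl on an amide-type nitrogen is the whole difference, with 4-fluoro-3-(trifluoromethyl)phenyl in place of 4-bromophenyl. Among the compounds with values here, no measured single-place step is available to size this swap. The expectation therefore rests on compound 2 at 1990 nM as the closest measured neighbour. The expected change a 1.3-fold higher number from compound 2 to compound 3 (0.10 log units; within the scatter) is estimated to stay within the scatter, with a slight lean toward a higher number. In this assay the estimate for compound 3 is 2500 nM with an expected range from 800 nM to 8000 nM for the coming measurement.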

Compound 3, half-maximal inhibitory concentration: 1110 nM
The estimate for compound 3 lay 2.3-fold (0.35 log units) above the measured number; low and high end bracket the measured number.
By their numbers in this assay, from the lowest: compounds 3 and 2 (each within the scatter of the next); then compound 1.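

On the amide-type nitrogen, 4-fluoro-3-(trifluoromethyl)phenyl in place of 4-bromophenyl gives, in this assay, a 1.8-fold lower number from compound 2 to compound 3 (0.25 log units; within the scatter) and so leaves the reading of compound 2 undisturbed. Within the data shown here, this is the first single-place step at this position, and it shows that the position tolerates a group with more heavy atoms and that the bromine is not needed for a number in this range, since compound 3 carries only fluorine as halogen. Nothing measured here bears on why the two groups read alike.

On these data alone, both groups are halogen-bearing phenyl rings, so it remains open whether a phenyl ring carrying an amine or a carboxylic acid, or an alkyl chain in place of the ring, would stay in this range. It also remains open which of its differences from compound 2 accounts for the higher number of compound 1.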